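Amide nitrogen variation on a shared fluorinated core

This account rests on a few compounds, and the source may have more. Where it says the series, first, only, none or still open, it means among the compounds named here.

Measured so far:
compound 1, `CNC(=O)/C=C1\CCc2c(F)cc(F)cc21`, gives 100%
compound 2, `O=C(/C=C1\CCc2c(F)cccc21)NC1CC1`, gives 100%

Both compounds were tested in a functional assay on the whole organism with Mus musculus as the target, at a dose of 100 mg/kg by the intraperitoneal route; a higher number here means more inhibition at the dose given (going by the name of the read-out), a lower number less inhibition. In this assay compound 1 gives 100%, and compound 2 gives 100%. Compound 1 therefore stands level with compound 2 at the digits recorded; the two values lie within the scatter of each other, so nothing can be said of an order between them. Within the data shown here, no pair here differs in a single place, so no measured step is available in this assay.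

The next compound, compound 3, `CCNC(=O)/C=C1\CCc2c(F)cc(F)cc21`, has not yet been measured. It differs from compound 1 by methyl in place of hydrogen on a saturated chain carbon bound to an amide-type nitrogen. Among the measured compounds shown here, only two compounds are known, both at the top of the read-out, so the effect of the change cannot be read from a measured step. The expectation is that the step from compound 1 to compound 3, a number 3 percentage points lower from compound 1 to compound 3 (within the scatter), will stay within the scatter, because compound 1 already gives 100% and compound 2 with a different amide substituent gives 100%. Compound 3 is estimated at 97%, with a range from 82% to 100%.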

Compound 3, a percentage reported as inhibition, in the whole organism at one dose (the size of the read-out at that dose, not a potency): 67%
For compound 3 the middle estimate is 30 percentage points above the measured one; the whole stated range lies above it.
By their numbers in this assay, from the lowest: compound 3; then compounds 1 and 2 (each within the scatter of the next).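

In this assay, among these compounds, the change from methylcarbamoyl to ethylcarbamoyl on the shared core gives a number 33 percentage points lower from compound 1 to compound 3 (beyond the scatter) and is the first measured step. The read-out is therefore not fixed at its top value for this set: methyl in place of hydrogen on a saturated chain carbon bound to an amide-type nitrogen is enough to move it clearly, which the two level compounds could not show. No measurement given here bears on why this change lowers the read-out.

Still open, from the compounds shown here alone, is whether the fall continues along a longer chain such as n-propyl, or whether a branched isopropyl group on the amide nitrogen behaves like the ethyl group of compound 3. Also open, going by these compounds, is how a cyclopropyl group on the amide nitrogen would read on the core of compound 1: compound 2 carries that group but differs from compound 3 in more than one place, so the two cannot be compared directly.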